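From compound 2 to compound 4: a 3-ureidopropyl chain

This account rests on a few compounds, and the source may have more. Where it says the series, first, only, none or still open, it means among the compounds named here.

In an ADME assay on microsomes from liver (Homo sapiens) for metabolic stability, using NADPH, with a stated time of 10 min (a lower number here means that less of the compound is left, a higher number that more of the compound is left), compound 2 `CN(C[C@H]1Cc2ncccc2CN1)[C@H]1CCCc2cccnc21` gives 95%, compound 3 `CN(C[C@@H]1Cc2ncccc2CN1)[C@H]1CCCc2cccnc21` gives 100% and compound 1 `NCCCCN(C[C@H]1Cc2cccnc2CN1)[C@H]1CCCc2cccnc21` gives 96%. All three lie within the scatter of one another, so compound 2 stands level with the other two.

Still unmeasured is compound 4 `NC(=O)NCCCCN(C[C@H]1Cc2ncccc2CN1)[C@H]1CCCc2cccnc21`, and the change leading to it from compound 2 is 3-ureidopropyl in place of hydrogen on a saturated chain carbon bound to an amine nitrogen. This places 3-ureidopropyl in place of hydrogen on a saturated chain carbon bound to an amine nitrogen. Cut one bond further out, the same difference reads methyl to 4-ureidobutyl.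

The series offers a single measured step, a number 5 percentage points higher from compound 2 to compound 3 (within the scatter). That step rests on the fact that compounds 2 and 3 differ only in the configuration as drawn and adds no chain, so it bears only weakly on the present change and does not size it. The remaining guide is the level of the series in this assay, with compound 1 at 96% and compound 2 at 95%. From the compounds shown here alone, no step beyond the scatter is therefore expected, although the range is kept wide on the lower side since this chain is untested here. The expected step is a number 3 percentage points lower from compound 2 to compound 4 (within the scatter). For compound 4 the estimated value is 92%, with an expected range of 78% to 100%.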

Compound 4, percent of the compound remaining: 91%
Compound 4: middle estimate off by 1 percentage points, on the high side, and the stated range covers the measured number.
By their numbers in this assay, from the lowest: compounds 4, 2, 1 and 3 (each within the scatter of the next).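

The change to 3-ureidopropyl in place of hydrogen on a saturated chain carbon bound to an amine nitrogen gives a number 4 percentage points lower from compound 2 to compound 4 (within the scatter) in this assay and leaves the read-out level with the parent. Within the data shown here, the only earlier step with a single difference concerned configuration alone, whereas this one shows that this position can carry a chain ending in a ureido group without a step beyond the scatter in this read-out. The structural information at hand does not address the added chain, so nothing here explains why the number holds.

Open, from the compounds shown here alone, is whether a carboxylic acid at the end of the chain, a hydroxyl group in place of the ureido group or a longer chain would stay level in this assay as well. Also open, going by these compounds, is whether the same 3-ureidopropyl change would stay level on the configuration drawn in compound 3, which gives 100% without the chain, and how much of the result belongs to the ureido group rather than to the chain that carries it.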